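Cytotoxicity notes: pyridylmethyl to cyclobutylmethyl swap

The compounds below may be only part of what the source reports. "The series", "measured", "known", "first", "only" and "open" are said of these compounds alone.

Compound 1 `CS(=O)(=O)Nc1ccc2c(c1)S(=O)(=O)N=C(C1=C(O)C3CCCC3N(Cc3ccccn3)C1=O)N2` stands at a limit in an ADME assay on Huh-7 cells (Homo sapiens) for cytotoxicity, with a stated time of 72 h; on this read-out higher numbers stand for lower toxicity in this test and lower numbers for higher toxicity in this test: compound 1 gives > 33000 nM, a limit of the assay rather than a number. Compound 2 `CS(=O)(=O)Nc1ccc2c(c1)S(=O)(=O)N=C(C1=C(O)[C@H]3CCC[C@H]3N(Cc3ccc(F)c(F)c3)C1=O)N2` also returns only a limit, > 1000 nM. Compound 3 `CS(=O)(=O)Nc1ccc2c(c1)S(=O)(=O)N=C(C1=C(O)[C@H]3CCC[C@H]3N(Cc3ccc(C(F)(F)F)cc3)C1=O)N2` likewise sits at a limit, > 33000 nM. Among the measured compounds shown here, the one single-point step measured, a step that the two limits leave unreadable from compound 2 to compound 3, cannot be read because both ends are limits. Compound 4 `CS(=O)(=O)Nc1ccc2c(c1)S(=O)(=O)N=C(C1=C(O)C3CCCC3N(CC3CCC3)C1=O)N2` differs from compound 1 by cyclobutyl in place of pyridin-2-yl on a saturated chain carbon bound to an amide-type nitrogen in a ring. For the measured compounds named here, no measured step bears on this change; what the series offers is the limit of > 33000 nM in this assay, at which 2 of the 3 values shown sit, with the limit of > 1000 nM in this assay, at which 1 of the 3 values shown sits, as the only exception. No shift beyond the scatter is therefore expected, and the expected step of a number no higher from compound 1 to compound 4 (the limit leaves the size open) is flat. Compound 4 is estimated to give 33000 nM, between 15000 nM and 100000 nM.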

Compound 4, half-maximal cytotoxic concentration: > 33000 nM
Compound 4: no number, only a limit; the forecaster's own chance of this, stated with the estimate: 80%; the middle value lies on the limit itself.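

Compound 1 and compound 4 both return only limits in this assay, and the step between them cannot be read. The compounds shown leave open what size, if any, the change from (pyridin-2-yl)methyl to cyclobutylmethyl has on cytotoxicity.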